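This account rests on a few compounds, and the source may have more. Where it says the series, first, only, none or still open, it means among the compounds named here.

Measured compounds:
- compound 1, `COc1ccc(-c2[nH]c3ccccc3c2/C=C(\C#N)S(=O)(=O)c2ccccc2)cc1`, in a functional assay on HCC 2998 cells (Homo sapiens) for inhibition, read by sulforhodamine B assay, with a stated time of 48 h (on this read-out lower numbers stand for stronger inhibition of growth and higher numbers for weaker inhibition of growth), compound 1 gives 1200 nM
- compound 2, `CC(=O)/C(=C\c1c(-c2ccccc2)[nH]c2ccccc12)S(=O)(=O)c1ccccc1`, in this assay compound 2 gives 1400 nM
- compound 3, `COc1ccc(-c2[nH]c3ccc(OC)cc3c2C=C(C#N)C#N)cc1`, in this assay compound 3 gives "not determined" (no result reported)

Compound 2 holds the higher of the two numbers obtained, yet its gap to compound 1 is within the scatter, so the two cannot be ranked against each other; compound 3 contributes no number.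

Compound 4, `N#C/C(=C\c1c(-c2ccccc2)[nH]c2ccccc12)S(=O)(=O)c1ccccc1`, differs from compound 2 in one place: cyano in place of acetyl on a double-bonded chain carbon bound to a double-bonded chain carbon and a sulfonyl sulfur. Going by the values given here, no pair of measured compounds separated by exactly this change is available, so the step has to be judged from the whole picture. Among the compounds with values here, compound 1, which also carries a cyano group at this position, sits within the scatter of compound 2, and nothing among the measured compounds points to a large shift in either direction. He therefore expects the step from compound 2 to compound 4 in this assay to be a 1.2-fold lower number from compound 2 to compound 4 (0.07 log units; within the scatter), a change that does not rise beyond the scatter. For compound 4 in this assay he estimates 1200 nM, with a range from 500 nM to 2800 nM.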

Compound 4, concentration for 50% growth inhibition: 10900 nM
Beside the measured number, compound 4's estimate is 9.1-fold (0.96 log units) below it; measured number outside the range, above it.
By their numbers in this assay, from the lowest: compounds 1 and 2 (each within the scatter of the next); then compound 4.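

In this assay, the exchange of acetyl for cyano on a double-bonded chain carbon bound to a double-bonded chain carbon and a sulfonyl sulfur is not a neutral one: it gives a 7.8-fold higher number from compound 2 to compound 4 (0.89 log units; beyond the scatter). With the cyano kept, hydrogen in place of methoxy on an aromatic carbon gives a 9.1-fold higher number from compound 1 to compound 4 (0.96 log units; beyond the scatter). The number of compound 1 therefore did not show what cyano does at this position without the methoxy, and compound 4 shows that acetyl and methoxy each go with a lower number than it has.

As far as these compounds go, whether a carboxylic acid or an amide at the chain carbon, or an amine on the aromatic carbon, would give a lower number remains open. Nothing available here explains either step.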